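From 4-fluorobenzyl to 2-methoxybenzyl in one small series

The source may report more compounds than this note shows. Statements on the series, on what has been measured and on what is new or still open speak of the compounds shown alone.

Compound 1 `OC[C@H]1O[C@@H](n2cnc3c(NCc4ccc(F)cc4)ncnc32)[C@H](O)[C@@H]1O` measures 2700 nM
Compound 2 `OC[C@H]1O[C@@H](n2cnc3c(NCc4ccccc4Br)ncnc32)[C@H](O)[C@@H]1O` measures 10000 nM
Compound 3 `OC[C@H]1O[C@@H](n2cnc3c(NCc4ccc(Br)cc4)ncnc32)[C@H](O)[C@@H]1O` measures 68200 nM

In a functional assay on K562 cells (Homo sapiens) for antiproliferative activity, with a stated time of 72 h (a higher number here means a weaker inhibitor, a lower number a stronger inhibitor), compound 1 holds the lowest of the three numbers. Compound 4 `COc1ccccc1CNc1ncnc2c1ncn2[C@@H]1O[C@H](CO)[C@@H](O)[C@H]1O` carries 2-methoxyphenyl in place of 4-fluorophenyl on a saturated chain carbon bound to a nitrogen on an aromatic ring and is still unmeasured. The nearest guide is the modest step of a 3.7-fold higher number from compound 1 to compound 2 (0.57 log units; beyond the scatter) in which 2-bromophenyl enters. The large step of a 25-fold higher number from compound 1 to compound 3 (1.40 log units; beyond the scatter) bears less on it, and the modest step of a 6.8-fold higher number from compound 2 to compound 3 (0.83 log units; beyond the scatter) separates the two bromo compounds. For the measured compounds named here, no measured compound carries a methoxy group, so the range stays wide. The expected outcome is a modest step, estimated as a 3.0-fold higher number from compound 1 to compound 4 (0.47 log units; beyond the scatter) in size. Compound 4 is estimated at 8000 nM in this assay with 2000 nM to 35000 nM as the expected range.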

Compound 4, half-maximal inhibitory concentration: 89000 nM
Estimate against measurement, compound 4: 11-fold (1.05 log units) below; measured number outside the range, above it.
By their numbers in this assay, from the lowest: compound 1; then compound 2; then compounds 3 and 4 (each within the scatter of the next).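

In this assay, the second group at this place on the ring decides much of the outcome: an 8.9-fold higher number from compound 2 to compound 4 (0.95 log units; beyond the scatter), so compound 2 was no guide to every 2-substituted phenyl, and the change from the 4-fluorophenyl compound is large, a 33-fold higher number from compound 1 to compound 4 (1.52 log units; beyond the scatter). With a 1.3-fold higher number from compound 3 to compound 4 (0.12 log units; within the scatter), the 2-methoxyphenyl and 4-bromophenyl compounds cannot be told apart. Nothing measured here accounts for these steps. The compounds shown leave open how 4-methoxyphenyl, 2-fluorophenyl or 2-hydroxyphenyl would read, and so whether the ring place or the group itself carries the change.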